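The source may hold more compounds than are shown below. What is called first, only, known or untested is meant among the compounds shown, and "the series" means these compounds.

Compound 1 `COc1ccc2c(c1)c(C1CC(c3ccccc3)=NN1C(=O)c1ccc(OC)nc1)cn2C` gives 1330 nM
Compound 2 `COc1ccc2c(c1)c(C1CC(c3ccc(F)cc3)=NN1C(=O)c1ccc(OC)nc1)cn2C` gives 220 nM
Compound 3 `COc1ccc2c(c1)c(C1CC(c3ccc(Cl)cc3)=NN1C(=O)c1ccc(OC)nc1)cn2C` gives 2080 nM

These values come from a functional assay on HepG2 cells (Homo sapiens) for inhibition, read by MTT assay, with a stated time of 48 h (a higher number here means a weaker inhibitor of growth, a lower number a stronger inhibitor of growth), and are best read as steps between compounds. Compound 3, with its 2080 nM reading, cannot be told apart from the unsubstituted compound, as the data show a 1.6-fold higher number from compound 1 to compound 3 (0.19 log units; within the scatter) here. Against the fluoro compound there is a clear gap, namely a 9.5-fold higher number from compound 2 to compound 3 (0.98 log units; beyond the scatter) in this series.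

Compound 4 `COc1ccc2c(c1)c(C1CC(c3ccc(Br)cc3)=NN1C(=O)c1ccc(OC)nc1)cn2C` carries bromo in place of chloro on an aromatic carbon, para to a large group (bromo in place of chloro on an aromatic carbon), which turns 4-chlorophenyl into 4-bromophenyl. Going by the values given here, no bromo compound has been measured, so only the other halogen steps can guide the expectation. The fluoro compound stands apart, with a 6.0-fold lower number from compound 1 to compound 2 (0.78 log units; beyond the scatter) as its step, but three compounds give no direction for bromo. The chloro step stayed small, and that is the closest guide. In this assay the expected step is a 1.0-fold lower number from compound 3 to compound 4 (0.02 log units; within the scatter) and so no change beyond the scatter is expected. Compound 4 is estimated at 2000 nM with an expected range from 800 nM to 5000 nM in this measurement.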

Compound 4, concentration for 50% growth inhibition: > 10000 nM
Compound 4 was reported as a limit; the forecaster's own chance of this, stated with the estimate: 3%; middle value at least 5.0-fold (0.69 log units) away from the limit.
By their numbers in this assay, from the lowest: compound 2; then compounds 1 and 3 (each within the scatter of the next). At a limit, above all of these: compound 4.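

Of the halogens shown, only bromo moves the number clearly upward, with an at least 7.5-fold higher number from compound 1 to compound 4 (0.87 log units; beyond the scatter) as its step, so this place on the ring does not treat all halogens alike. Even the swap of chloro for bromo is a real change, with an at least 4.8-fold higher number from compound 3 to compound 4 (0.68 log units; beyond the scatter) in this series, and replacing fluoro with bromo gives an at least 45-fold higher number from compound 2 to compound 4 (1.65 log units; beyond the scatter) overall. All three steps are minimum sizes, as the reading for compound 4 is a limit of the assay and not a number: the limit of > 10000 nM in this assay, at which 1 of the 4 values shown sits.

Going by these compounds, how far the true value of compound 4 lies beyond that limit stays open. So does how a methyl, methoxy or trifluoromethyl group at this place would read, and the halogen results alone cannot settle that.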